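This account rests on a few compounds, and the source may have more. Where it says the series, first, only, none or still open, it means among the compounds named here.

In a physicochemical assay for solubility, in phosphate buffer, at pH 7.4 (a lower number here means a less soluble compound, a higher number a more soluble compound), compound 1 `CCOC(=O)c1c(-c2ccccc2C)[nH]c2cc(OC)ccc2c1=O` gives > 100000 nM, which is a limit of the assay and not a number. Compound 2 `CCOC(=O)c1c(-c2ccc(OC)cc2)[nH]c2cccc(OC)c2c1=O` gives > 100000 nM, also a limit. Compound 3 `CCOC(=O)c1c(-c2cccc(F)c2)[nH]c2cccc(OC)c2c1=O` gives > 100000 nM, again a limit. All three therefore stand at the limit of > 100000 nM in this assay, at which 3 of the 3 values shown sit. Compound 4 `CCOC(=O)c1c(-c2cccc([N+](=O)[O-])c2)[nH]c2cc(OC)ccc2c1=O` departs from compound 1 by 3-nitrophenyl in place of 2-methylphenyl on an aromatic carbon, with the new group on the aromatic carbon next to the ring nitrogen. The nearest measured exchange of one substituted phenyl for another is a step that the two limits leave unreadable from compound 2 to compound 3, and it offers no size to carry over. No step beyond the scatter is therefore expected in this assay, and no direction can be read. The expected change is a number no higher from compound 1 to compound 4 (the limit leaves the size open). For compound 4 the estimate is 100000 nM, within an expected range of 30000 nM to 150000 nM.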

Compound 4, solubility: 13000 nM
The estimate for compound 4 lay 7.7-fold (0.89 log units) above the measured number, outside the stated range (below it).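

In this assay, the substituted phenyl on the aromatic carbon next to the ring nitrogen is shown to matter: 3-nitrophenyl in place of 2-methylphenyl gives an at least 7.6-fold lower number from compound 1 to compound 4 (0.88 log units; beyond the scatter). Compound 4 is the first compound here with a number and not a limit: the limit of > 100000 nM in this assay, at which 3 of the 4 values shown sit.

This one exchange changes both the group on the phenyl ring and its place there, and the compounds shown do not separate the two. Going by these compounds, how 3-methylphenyl, 2-nitrophenyl, or a phenyl carrying an amine or a carboxylic acid would read at this position remains open.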